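The compounds below may be only part of what the source reports. "The series", "measured", "known", "first", "only" and "open" are said of these compounds alone.

Of the compounds shown here, three sharing one core have been tested in an assay on isolated protein for binding affinity to histone acetyltransferase KAT2B (Homo sapiens), read by fluorescence, tested at 10 uM; on this read-out lower numbers stand for weaker stabilisation of the target and higher numbers for stronger stabilisation of the target against heat. Compound 1 `C=CCCn1c(N[C@@H]2C[C@H](c3ccccc3)CN(C)C2)nc2cc[nH]c2c1=O` gives 1.5 degrees C in this assay. Compound 2 `C=CCn1c(N[C@@H]2C[C@H](c3ccccc3)CN(C)C2)nc2cc[nH]c2c1=O` gives 2.2 degrees C. Compound 3 `CC=CCn1c(N[C@@H]2C[C@H](c3ccccc3)CN(C)C2)nc2cc[nH]c2c1=O` gives 1.5 degrees C, which leaves compound 3 level with compound 1 and, together with it, at the lowest of the three numbers, while the remaining gap reads a number 0.70 degrees C lower from compound 2 to compound 3 (within the scatter). The chain carried on the saturated chain carbon bound to the aromatic nitrogen has so far been varied without any step beyond the scatter: a number 0.70 degrees C higher from compound 1 to compound 2 (within the scatter) and no change at the digits printed from compound 1 to compound 3 (within the scatter).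

Compound 4 `CCn1c(N[C@@H]2C[C@H](c3ccccc3)CN(C)C2)nc2cc[nH]c2c1=O` is not yet measured. Compared with compound 3 it shows (methyl in place of prop-1-en-1-yl on a saturated chain carbon bound to an aromatic nitrogen). The same difference, cut one bond further out, reads but-2-en-1-yl to ethyl. The measured steps that bear on it are those that alter this same chain, and all three lie within the scatter. Because those steps, a number 0.70 degrees C higher from compound 1 to compound 2 (within the scatter), no change at the digits printed from compound 1 to compound 3 (within the scatter) and a number 0.70 degrees C lower from compound 2 to compound 3 (within the scatter), stayed inside the scatter, the step to compound 4 is expected to be a number 0.10 degrees C higher from compound 3 to compound 4 (within the scatter), that is no change beyond the scatter in this assay. Compound 4 is therefore estimated at 1.6 degrees C, with a range from 0.5 degrees C to 2.7 degrees C.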

Compound 4, shift of the target's melting temperature: 4.8 degrees C
Compound 4: middle estimate off by 3.2 degrees C, on the low side; measured number outside the range, above it.
By their numbers in this assay, from the lowest: compounds 1, 3 and 2 (each within the scatter of the next); then compound 4.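

In this assay, the chain on the saturated chain carbon bound to an aromatic nitrogen now gives its first steps beyond the scatter, all three ending at the ethyl chain of compound 4 (a number 3.3 degrees C higher from compound 3 to compound 4 (beyond the scatter); a number 2.6 degrees C higher from compound 2 to compound 4 (beyond the scatter); a number 3.3 degrees C higher from compound 1 to compound 4 (beyond the scatter)). This position is therefore not indifferent to its substituent, as the earlier steps among the three alkene-bearing chains had suggested: those chains stay within the scatter of one another, while the ethyl chain stands apart from each of them, and among these compounds no chain goes against that split. Nothing given here explains the difference, and the data offer no measured property of these chains that could account for it.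

The compounds shown leave open whether the rise goes with the shorter chain or with the loss of the double bond, since the two change together in every step to compound 4, and a saturated propyl or butyl chain would separate them. They also leave open how the number responds to a still smaller group here, such as a methyl, or to a chain ending in a hydroxyl or an amine.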